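A few compounds are considered here, and "the series" means these few. Any claim that something is new, unique, unknown or untested is made for them only; others in the source may bear on it.

Compound 1 `C#Cc1cccc(Nc2ncnc3cc(OC)c(OCCCCC(=O)Nc4ccc(S(N)(=O)=O)cc4)cc23)c1` gave 17700 nM in a functional assay on A-431 cells (Homo sapiens) for antiproliferative activity, read by MTT assay, with a stated time of 72 h; on this read-out higher numbers stand for weaker inhibition and lower numbers for stronger inhibition; compound 2 `COc1cc2ncnc(Nc3cccc(Cl)c3)c2cc1OCCCCC(=O)Nc1ccc(S(N)(=O)=O)cc1` gave 30400 nM; compound 3 `COc1cc2ncnc(Nc3cccc(C)c3)c2cc1OCCCCC(=O)Nc1ccc(S(N)(=O)=O)cc1` gave 7460 nM.

Compound 2 carries the highest number of the three, though one of its gaps (a 1.7-fold higher number from compound 1 to compound 2 (0.23 log units; within the scatter)) lies within the scatter, while the other (a 4.1-fold lower number from compound 2 to compound 3 (0.61 log units; beyond the scatter)) lies beyond it. Compound 4 `CCc1ccc(Nc2ncnc3cc(OC)c(OCCCCC(=O)Nc4ccc(S(N)(=O)=O)cc4)cc23)cc1` differs from compound 2 by 4-ethylphenyl in place of 3-chlorophenyl on a nitrogen on an aromatic ring. The step that bears on this is the exchange of chloro for methyl, a 4.1-fold lower number from compound 2 to compound 3 (0.61 log units; beyond the scatter), a modest drop in number; the entering group here, like methyl, is built of carbon only, so a modest drop of similar size is expected. Compound 4 is therefore expected to give 10000 nM (3500 nM to 30000 nM), a step of a 3.0-fold lower number from compound 2 to compound 4 (0.48 log units; beyond the scatter).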

Compound 4, half-maximal inhibitory concentration: 7220 nM
Beside the measured number, compound 4's estimate is 1.4-fold (0.14 log units) above it; measured number inside the range.
By their numbers in this assay, from the lowest: compounds 4 and 3 (each within the scatter of the next); then compounds 1 and 2 (each within the scatter of the next).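

Placing 4-ethylphenyl on this nitrogen lowers the number compared with 3-chlorophenyl (a 4.2-fold lower number from compound 2 to compound 4 (0.62 log units; beyond the scatter)) and with 3-ethynylphenyl (a 2.5-fold lower number from compound 1 to compound 4 (0.39 log units; beyond the scatter)), yet compared with 3-methylphenyl it makes no readable difference (a 1.0-fold lower number from compound 3 to compound 4 (0.01 log units; within the scatter)). A ring carrying methyl or ethyl therefore gives lower numbers here than one carrying chloro or ethynyl. Ethynyl is also built of carbon only, so compound 1 goes against the expectation that any carbon-only group gives this drop.

From the compounds shown here alone, compound 4 changes both the group and where it sits on the ring, so 3-ethylphenyl would be needed to separate the two, and the effect of a butyl chain or an amine on this ring remains open. Nothing available here explains why these groups differ.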